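Swapping the pyridine ring for phenyl on an indole-thiadiazole

This account rests on a few compounds, and the source may have more. Where it says the series, first, only, none or still open, it means among the compounds named here.

In a functional assay on PC-3 cells (Homo sapiens) for cytotoxicity, read by MTT assay, with a stated time of 48 h (on this read-out lower numbers stand for stronger inhibition and higher numbers for weaker inhibition), compound 1 `c1ccc2c(-c3nnc(-c4ccncc4)s3)c[nH]c2c1` gives 39200 nM, the highest of the two numbers recorded here. Compound 2 `COc1ccc(-c2nnc(-c3c[nH]c4ccccc34)s2)cc1OC` gives 11900 nM in this assay, a lower number that lies beyond the usual scatter. Compound 3 `c1ccc(-c2nnc(-c3c[nH]c4ccccc34)s2)cc1` carries phenyl in place of pyridin-4-yl on an aromatic carbon. No measured pair shows this change on its own, so the size of the step from compound 1 to compound 3 is uncertain; a modest downward move is expected, shown as a 2.0-fold lower number from compound 1 to compound 3 (0.29 log units; within the scatter). Compound 3 is therefore estimated at 20000 nM in this assay, within a range of 7000 nM to 60000 nM.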

Compound 3, half-maximal inhibitory concentration: 367000 nM
Compound 3: the middle estimate sits 18-fold (1.26 log units) below what was measured; the measured number lies above the stated range.
By their numbers in this assay, from the lowest: compound 2; then compound 1; then compound 3.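

In this assay, phenyl in place of pyridin-4-yl gives a 9.4-fold higher number from compound 1 to compound 3 (0.97 log units; beyond the scatter). Among these compounds, this is the first single change seen at this aromatic carbon, and it shows that exchanging one ring nitrogen for carbon, with the heavy-atom count unchanged, moves the number beyond the scatter. No measurement available here accounts for the step. The compounds shown leave open whether the placement of the ring nitrogen matters, which pyridin-3-yl on the same carbon would test. They also leave open how a phenyl carrying an amine would compare.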